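Fluorine on the benzyl group in a binding series

The compounds below may be only part of what the source reports. "The series", "measured", "known", "first", "only" and "open" are said of these compounds alone.

Within the data shown here, compound 1 `O=C(c1c2c(nn1-c1ccccc1)CCC(NCc1ccccc1)C2)N1CCCCC1` in an assay on HEK293 cells for displacement of a labelled ligand from Sigma non-opioid intracellular receptor 1 (Homo sapiens), read by scintillation counting, with a stated time of 120 min (a higher number here means a weaker inhibitor, a lower number a stronger inhibitor), gives 39.8 nM, the only single number so far in this set. Of the other two measured compounds, compound 2 reaches only a limit and compound 3 carries more than one entry. Compound 2 `CCCn1nc(C(=O)N(C)C)c2c1CCC(OCc1ccc(F)cc1)C2` reaches only the limit > 10000 nM in this assay. Compound 3 `O=C(c1c2c(nn1-c1ccc(F)cc1)CCC(NCc1ccc(F)cc1)C2)N1CCCCC1` gives 15.9 nM; 17 nM (2 entries) in this assay, and the several entries of compound 3 in this assay, 15.9 nM; 17 nM (2 entries) shows how close its repeated entries lie to each other. Compound 4 `O=C(c1c2c(nn1-c1ccccc1)CCC(NCc1ccc(F)cc1)C2)N1CCCCC1` has not yet been measured in this assay. It differs from compound 1 in one place: fluoro in place of hydrogen on an aromatic carbon. Among the measured compounds shown here, no measured pair differs in a single place, so the size of this step has no direct precedent. Compound 3 carries the 4-fluorobenzyl group together with a second fluorine, and its values sit below that of compound 1. The step to compound 4 is therefore expected to be small, toward somewhat stronger inhibition if anything, and likely within the scatter of repeats. Compound 4 is expected to give about 25 nM in this assay, with a range from 12 nM to 60 nM. The expected step is a 1.6-fold lower number from compound 1 to compound 4 (0.20 log units; within the scatter).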

Compound 4, inhibition constant: 31.6 nM
Compound 4: middle estimate off by 1.3-fold (0.10 log units), on the low side; low and high end bracket the measured number.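

Fluoro in place of hydrogen on an aromatic carbon, the change from benzyl to 4-fluorobenzyl, gives in this assay a 1.3-fold lower number from compound 1 to compound 4 (0.10 log units; within the scatter). Among these compounds, this is the first single-place reading, and it shows that this position takes the fluorine without a change beyond the scatter, which compound 3, with its second fluorine, could not show. Nothing measured here accounts for the size of this step.

Among the compounds shown here, compound 3 gives 15.9 nM; 17 nM (2 entries) and compound 4 gives 31.6 nM, but what the second fluorine contributes on its own stays open, with no step to read for that pair. Also open, as far as these compounds go, is whether a chloro, methoxy or trifluoromethyl group on the same aromatic carbon would move the number beyond the scatter, or whether this position stays as flat for those groups as it does for fluoro.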